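The source may hold more compounds than are shown below. What is called first, only, known or untested is meant among the compounds shown, and "the series" means these compounds.

Working notes on the series, on a functional assay for inhibition, tested at 80 ug/mL; on this read-out lower numbers stand for a weaker effect and higher numbers for a stronger effect at the one concentration tested.

Two compounds have numbers. Compound 1 `COc1ccc(-c2cc(-c3cc(C(C)C)c(O)cc3C)[nH]c(=O)c2C#N)cc1` gives 47.5% in this assay. Among the measured compounds shown here, compound 2 `COc1ccc(-c2cc(-c3cc(C(C)C)c(O)cc3C)[nH]c(=O)c2C#N)cc1OC` gives 58% in this assay, the higher of the two numbers, and compound 1 is the nearest, with the only measured step being a number 10.5 percentage points higher from compound 1 to compound 2 (beyond the scatter).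

Compound 3 `Cc1cc(O)c(C(C)C)cc1-c1cc(-c2ccccc2[N+](=O)[O-])c(C#N)c(=O)[nH]1` has not been measured. It differs from compound 2 by 2-nitrophenyl in place of 3,4-dimethoxyphenyl on an aromatic carbon, on an aromatic carbon ortho to a cyano group and opposite the ring nitrogen. For the measured compounds named here, the one measured step concerns a single methoxy on this same six-membered aromatic ring and bears only loosely on the change at hand, which removes both methoxy groups and brings in a nitro group. Taking the loss of the methoxy groups alone would point back toward the number of compound 1, so a downward step of modest size is expected, a number 13 percentage points lower from compound 2 to compound 3 (beyond the scatter), with wide uncertainty. Compound 3 is therefore estimated at 45% in this assay, with a range from 25% to 65%.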

Compound 3, a percentage reported as inhibition, at one concentration (the size of the read-out at that concentration, not a potency): 35%
Compound 3: middle estimate off by 10 percentage points, on the high side; low and high end bracket the measured number.
By their numbers in this assay, from the lowest: compound 3; then compound 1; then compound 2.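

In this assay exchange of 3,4-dimethoxyphenyl for 2-nitrophenyl on this aromatic carbon, ortho to a cyano group and opposite the ring nitrogen, gives a number 23 percentage points lower from compound 2 to compound 3 (beyond the scatter) and exchange of 4-methoxyphenyl for 2-nitrophenyl gives a number 12.5 percentage points lower from compound 1 to compound 3 (beyond the scatter) in the same direction. Compound 3 therefore stands lowest of the three, so the read-out at this position can fall as well as rise with the choice of substituted phenyl group. Nothing on hand gives a reason for these steps.

On these data alone, compound 3 loses the methoxy groups and gains the nitro group in a single change, so the share of each in the drop stays open. An unsubstituted phenyl group, or a phenyl group carrying an amine or a carboxylic acid, would be needed to separate the two and to show how far this position extends beyond these groups.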